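The source may report more compounds than this note shows. Statements on the series, on what has been measured and on what is new or still open speak of the compounds shown alone.

Measured compounds:
- compound 1, `CCCCC(N)c1cc(C(F)(F)F)ccc1N1CCN(C(=O)CCc2ccc(Cl)cc2Cl)CC1`, 190 nM
- compound 2, `COc1cccc(CCC(=O)N2CCN(c3ccc(C(F)(F)F)cc3[C@@H](N)CC(C)C)CC2)c1`, 4000 nM
- compound 3, `COc1cc(OC)c(OC)cc1CCC(=O)N1CCN(c2ccc(C(F)(F)F)cc2[C@@H](N)CC(C)C)CC1`, 6100 nM

In an assay on HEK293 cells for displacement of a labelled ligand from Melanocortin receptor 4 (Homo sapiens) (on this read-out lower numbers stand for stronger inhibition and higher numbers for weaker inhibition), compound 1 gives the lowest of the three numbers. Compound 2 sits well above it, and compound 3 higher still; both gaps are beyond the scatter, so compound 1 is the most potent of the three on this read-out. For the measured compounds named here, the one measured step, a 1.5-fold higher number from compound 2 to compound 3 (0.18 log units; within the scatter), lies within the scatter and concerns the aryl end of the amide side chain, not the benzylic amine.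

The compound not yet measured is compound 4, `CCN[C@H](c1cc(C(F)(F)F)ccc1N1CCN(C(=O)CCc2ccc(Cl)cc2Cl)CC1)C(C)CC`. It differs from compound 1 in one place: 1-(ethylamino)-2-methylbutyl in place of 1-aminopentyl on an aromatic carbon. Going by the values given here, no measured pair touches this position, and the single step on record says nothing about the benzylic amine, so there is no direct guide for the direction of the step in this assay. The absence of any bearing step leaves the expectation anchored on compound 1 alone, with a wide margin.

Compound 4 is therefore expected to give about 250 nM in this assay, within a range of 60 nM to 1200 nM, which means an expected step of a 1.3-fold higher number from compound 1 to compound 4 (0.12 log units; within the scatter), not beyond the scatter.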

Compound 4, inhibition constant: 92 nM
For compound 4 the middle estimate is 2.7-fold (0.43 log units) above the measured one; measured number inside the range.
By their numbers in this assay, from the lowest: compound 4; then compound 1; then compounds 2 and 3 (each within the scatter of the next).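

In this assay, for the compounds shown here, 1-(ethylamino)-2-methylbutyl in place of 1-aminopentyl on this aromatic carbon gives a 2.1-fold lower number from compound 1 to compound 4 (0.31 log units; beyond the scatter), the first measured step at this position and a modest one. The entering group has 8 heavy atoms against 6 in the group it replaces and brings 1 defined stereocentre, yet the number goes lower, so on this read-out the position accepts the larger group without any loss of inhibition. The ethyl on the nitrogen and the methyl on the chain change together, the step cannot be divided between them, and nothing shown accounts for it.

The compounds shown leave open what the ethyl on the nitrogen and the 2-methyl branch each contribute, and how a dimethylamino group, a cyclopropylmethylamino group or a hydroxyl in place of the amine would read at this position. Also open, from the compounds shown here alone, are the opposite stereocentre of compound 4 and whether this change would give a similar step alongside the 3-methoxyphenyl side chain of compound 2 or the 2,4,5-trimethoxyphenyl side chain of compound 3.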